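Benzothiophene to Methylpyrimidine: Expected Shift in Cytotoxicity

The source may hold more compounds than are shown below. What is called first, only, known or untested is meant among the compounds shown, and "the series" means these compounds.

Of the compounds shown here, two have been measured in a toxicity assay on MT4 cells (Homo sapiens) for cytotoxicity, read by MTT assay, with a stated time of 5 days; on this read-out higher numbers stand for lower toxicity in this test and lower numbers for higher toxicity in this test. Compound 1 `Cc1cnc(Nc2ccc(C#N)cc2)nc1Nc1c(F)cc(-c2cccnc2)cc1F` gives 1100 nM in this assay, whereas compound 2 `Cc1cc(-c2cc3ccccc3s2)cc(C)c1Nc1ccnc(Nc2ccc(C#N)cc2)n1` gives 138000 nM. Compound 2 therefore holds the higher of the two numbers, and its gap to compound 1 lies well beyond the usual scatter, so compound 2 is plainly the less toxic of the pair in this assay. Compound 3 `Cc1ncc(-c2cc(C)c(Nc3ccnc(Nc4ccc(C#N)cc4)n3)c(C)c2)cn1` has not yet been measured; it differs from compound 2 in one place: 2-methylpyrimidin-5-yl in place of 1-benzothiophen-2-yl on an aromatic carbon. For the measured compounds named here, no measured pair isolates this change, so any expectation rests on compound 2 itself and on compound 1, which carries a nitrogen-containing six-membered ring and gives 1100 nM. The step of a 2.3-fold lower number from compound 2 to compound 3 (0.36 log units; beyond the scatter) is expected to be a modest drop, not far outside the scatter. Compound 3 is estimated at 60000 nM, with a range from 12000 nM to 200000 nM.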

Compound 3, half-maximal cytotoxic concentration: 3900 nM
Compound 3: the middle estimate sits 15-fold (1.19 log units) above what was measured; the measured number lies below the stated range.
By their numbers in this assay, from the lowest: compound 1; then compound 3; then compound 2.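

The aromatic carbon meta to two methyl groups and para to a large group proves far from neutral in this assay, since 2-methylpyrimidin-5-yl in place of 1-benzothiophen-2-yl gives a 35-fold lower number from compound 2 to compound 3 (1.55 log units; beyond the scatter), a large step towards higher toxicity in this test. For the compounds shown here, this is the first pair separated by a single change, and it shows that the group at this one position alone can move the read-out well beyond the scatter. Nothing available here accounts for the size of this step.

The compounds shown leave open whether the step follows from the ring nitrogens, the methyl group or the loss of the benzothiophene's second ring. From the compounds shown here alone, neither a plain phenyl nor an amine on the pyrimidine appears at this position, so how either would read remains unknown.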